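A few compounds are considered here, and "the series" means these few. Any claim that something is new, unique, unknown or untested is made for them only; others in the source may bear on it.

Compound 1 `[O-][S+](CCC(F)=C(F)F)c1ncc(-c2ccncc2)s1` reaches only the limit > 120000 nM in this study's cytotoxicity test.
Compound 2 `[O-][S+](CCC(F)=C(F)F)c1nccs1` likewise stands at the limit > 120000 nM.
Compound 3 `O=S(=O)(CCC(F)=C(F)F)c1ncc(-c2ccncc2)s1` also sits at the limit > 120000 nM.

All three values come from a functional assay on HepG2 cells (Homo sapiens) for cytotoxicity, read by MTT assay, with a stated time of 48 h; a lower number here means a stronger inhibitor, a higher number a weaker inhibitor. The change from compound 1 to compound 2 is hydrogen in place of pyridin-4-yl on an aromatic carbon, and its step that the two limits leave unreadable from compound 1 to compound 2 cannot be read, because of the limit of > 120000 nM in this assay, at which 3 of the 3 values shown sit. How the core of compound 3 differs from that of compound 1 is not broken down here. Compound 4 `O=S(=O)(CCC(F)=C(F)F)c1nccs1` carries the same kind of change as compound 2, namely (hydrogen in place of pyridin-4-yl on an aromatic carbon); the place lines differ only in that the neighbouring ring atom bears a group of 9 heavy atoms in compound 1 but a large group in compound 3. Given that compound 3 gives > 120000 nM, the step that the limit leaves unreadable from compound 3 to compound 4 is expected to be small. Compound 4 is estimated at 150000 nM, most likely again a limit.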

Compound 4, half-maximal inhibitory concentration: > 120000 nM
Compound 4 gave a limit, no number (the forecaster's own chance of this, stated with the estimate: 90%); the middle value is on the limit's open side.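

Compound 3 and compound 4 both stand at a limit, so no step between them can be read: the limit of > 120000 nM in this assay, at which 4 of the 4 values shown sit.

The compounds shown leave open whether hydrogen in place of pyridin-4-yl changes anything in this assay, and at what concentration any of these compounds would reach half-maximal inhibition.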